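Sesquiterpene oxime and benzylidene triazoles: cytotoxicity notes

A few compounds are considered here, and "the series" means these few. Any claim that something is new, unique, unknown or untested is made for them only; others in the source may bear on it.

Measured compounds:
compound 1 `CC(C)=CCC/C(C)=C/CC/C(C)=C/CC[C@@H]1[C@@]2(C)CC/C(=N\OCc3cn(-c4cccc([N+](=O)[O-])c4)nn3)C(C)(C)[C@@H]2CC[C@@]1(C)O` 14800 nM
compound 2 `CC(C)=CCC/C(C)=C/CC/C(C)=C/CC[C@@H]1[C@@]2(C)CC/C(=N\OCc3cn(-c4cccc(C(F)(F)F)c4)nn3)C(C)(C)[C@@H]2CC[C@@]1(C)O` 12900 nM
compound 3 `CC(C)=CCC/C(C)=C/CC/C(C)=C/CC[C@@H]1[C@@]2(C)C/C(=C\c3ccc(OCc4cn(-c5cccc([N+](=O)[O-])c5)nn4)cc3)C(=O)C(C)(C)[C@@H]2CC[C@@]1(C)O` 126000 nM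

In a functional assay on A549 cells (Homo sapiens) for cytotoxicity, read by MTT assay, with a stated time of 48 h (a higher number here means a weaker inhibitor, a lower number a stronger inhibitor), compound 1 and compound 2 differ by trifluoromethyl in place of nitro on an aromatic carbon, and the step was a 1.1-fold lower number from compound 1 to compound 2 (0.06 log units; within the scatter). Compound 3 carries the nitro group on a different core; the difference between the two cores is not broken down here. In this assay compound 3 gives 126000 nM, the highest number of the three.

Compound 4 `CC(C)=CCC/C(C)=C/CC/C(C)=C/CC[C@@H]1[C@@]2(C)C/C(=C\c3ccc(OCc4cn(-c5cccc(C(F)(F)F)c5)nn4)cc3)C(=O)C(C)(C)[C@@H]2CC[C@@]1(C)O` is not yet measured. It differs from compound 3 by trifluoromethyl in place of nitro on an aromatic carbon, the same change as between compound 1 and compound 2. The expectation for compound 4 rests on that earlier step, because a 1.1-fold lower number from compound 1 to compound 2 (0.06 log units; within the scatter) lay within the scatter, so the step from compound 3 to compound 4 is expected to be a 1.1-fold lower number from compound 3 to compound 4 (0.04 log units; within the scatter). For compound 4 the estimate in this assay is 115000 nM, between 50000 nM and 260000 nM.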

Compound 4, half-maximal inhibitory concentration: 23200 nM
Compound 4: the middle estimate sits 5.0-fold (0.70 log units) above what was measured; measured number below the stated range.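

In this assay, trifluoromethyl in place of nitro gave a 5.4-fold lower number from compound 3 to compound 4 (0.73 log units; beyond the scatter), so the size of the step seen on the core of compound 1 did not carry over to the core of compound 3: the same change on two cores in this assay, a 1.1-fold lower number (0.06 log units; within the scatter) from compound 1 to compound 2 and a 5.4-fold lower number (0.73 log units; beyond the scatter) from compound 3 to compound 4, 4.7-fold (0.68 log units) apart, beyond the scatter of two such steps. The size of this change therefore cannot be taken as constant from one core to the other in this series. These two pairs do not show which feature of the cores accounts for the gap, and they give no rule for any further core.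

On these data alone, it remains open whether a nitrile or an amine in place of nitro would also give steps that differ between the two cores. Which part of the difference between the cores matters also remains open.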